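From 3-methylphenyl to 3-methoxyphenyl in compound 3

The source may report more compounds than this note shows. Statements on the series, on what has been measured and on what is new or still open speak of the compounds shown alone.

In a functional assay on M21 cells (Homo sapiens) for antiproliferative activity, read by sulforhodamine B assay, with a stated time of 48 h (on this read-out higher numbers stand for weaker inhibition and lower numbers for stronger inhibition), compound 1 `CCCN1CCN(c2ccc(S(=O)(=O)Oc3ccccc3C)cc2)C1=O` reports only a limit, > 100000 nM. Compound 2 `CCCN1CCN(c2ccc(S(=O)(=O)Oc3ccccc3CC)cc2)C1=O` also reports only a limit, > 50000 nM. Among the compounds with values here, compound 3 `CCCN1CCN(c2ccc(S(=O)(=O)Oc3cccc(C)c3)cc2)C1=O` gives 28000 nM, the only true number of the three. Exchanging the aryl group on the oxygen gave an at least 3.5-fold lower number from compound 1 to compound 3 (0.55 log units; beyond the scatter) and an at least 1.7-fold lower number from compound 2 to compound 3 (0.25 log units; that floor lies within the scatter). Compound 4 `CCCN1CCN(c2ccc(S(=O)(=O)Oc3cccc(OC)c3)cc2)C1=O` has methoxy in place of methyl on an aromatic carbon. Within the data shown here, no measured step changes methyl to methoxy, and the steps above only show that 3-methylphenyl is the one measurable member. Nothing beyond the scatter is expected in this assay, and the expected change is a 1.4-fold lower number from compound 3 to compound 4 (0.15 log units; within the scatter). For compound 4 the estimate is 20000 nM, with an expected range of 7000 nM to 60000 nM.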

Compound 4, half-maximal inhibitory concentration: 10000 nM
Beside the measured number, compound 4's estimate is 2.0-fold (0.30 log units) above it, and the stated range covers the measured number.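

In this assay, within the data shown here, this is the first step on the 3-substituted phenyl with true numbers at both ends: a 2.8-fold lower number from compound 3 to compound 4 (0.45 log units; beyond the scatter). Methoxy in place of methyl on this aromatic carbon therefore moves the number beyond the scatter, and the distance from the 2-substituted groups widens, with an at least 5.0-fold lower number from compound 2 to compound 4 (0.69 log units; beyond the scatter) and an at least 10-fold lower number from compound 1 to compound 4 (1.00 log units; beyond the scatter). Both of these are floors only, as compound 1 and compound 2 report limits and not numbers.

Nothing shown here gives a cause for the step from methyl to methoxy. From the compounds shown here alone, whether ethoxy, hydroxy or an amine on this aromatic carbon would lower the number further stays open.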